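Extending the Alkyl Chain Four Bonds from a Sulfur

The compounds below may be only part of what the source reports. "The series", "measured", "known", "first", "only" and "open" are said of these compounds alone.

Measured compounds:
Compound 1, `Cc1cn([C@H]2C[C@H](SSc3ccc([N+](=O)[O-])cc3)[C@@H](CO)O2)c(=O)[nH]c1=O`, in a physicochemical assay for metabolic stability, in the presence of a further agent that is not named here (on this read-out lower numbers stand for a shorter-lived compound and higher numbers for a longer-lived compound), gives < 0.167 h, which is a limit of the assay rather than a number.
Compound 2, `CCCCSS[C@H]1C[C@H](n2cc(C)c(=O)[nH]c2=O)O[C@@H]1CO`, in this assay gives < 8 h, which is also a limit of the assay.

Compound 2 therefore stands only at a limit in this assay, at the limit of < 8 h in this assay, at which 1 of the 2 values shown sits. For the measured compounds named here, the one further value shown for this read-out, that of compound 1, sits at the limit of < 0.167 h in this assay, at which 1 of the 2 values shown sits. Going by the values given here, the single measured step, a step that the two limits leave unreadable from compound 1 to compound 2, exchanges the group directly on the sulfur and its size cannot be read, since both of its ends are limits. Among the compounds with values here, it does not touch the chain carbon altered here, so no measured step bears on the change to compound 3 in a readable way.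

Compound 3, `CCCCCCSS[C@H]1C[C@H](n2cc(C)c(=O)[nH]c2=O)O[C@@H]1CO`, differs from compound 2 by ethyl in place of hydrogen on a saturated chain carbon, four bonds along the chain from a sulfur. With nothing measured to guide it, the step expected in this assay is none beyond the scatter, estimated as a step that the limit leaves unreadable from compound 2 to compound 3. Compound 3 is accordingly expected near 4 h, within a range from 1 h to 16 h, with a real chance that only a limit is reported.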

Compound 3, half-life: < 8 h
Compound 3: no number, only a limit (the forecaster's own chance of this, stated with the estimate: 50%); the middle value lies beyond the limit too.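

Compound 3, like compound 1 and compound 2, stands only at a limit in this assay, so neither the step from compound 2 to compound 3 nor the step from compound 1 to compound 3 can be read. The compounds shown leave open how long any of the three actually lasts, and whether lengthening the butyl chain to hexyl changes the half-life at all.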